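This account rests on a few compounds, and the source may have more. Where it says the series, first, only, none or still open, it means among the compounds named here.

Values measured in an ADME assay on cells (Hepatocyte, Mus musculus) for cytotoxicity, read by MTT assay, with a stated time of 24 h; a lower number here means that less compound is tolerated, a higher number that more compound is tolerated:
- compound 1 `Cc1ccc(-c2nn(-c3ccccc3)cc2-c2nc3ccccc3n2S(=O)(=O)c2ccc(Br)cc2)cc1`: > 300000 nM (a limit of the assay)
- compound 2 `Cc1ccc(-c2nn(-c3ccccc3)cc2-c2nc3ccccc3n2S(=O)(=O)c2ccc(C(F)(F)F)cc2)cc1`: 89300 nM
- compound 3 `O=S(=O)(c1ccccc1)n1c(-c2cn(-c3ccccc3)nc2-c2ccc(F)cc2)nc2ccccc21`: 231000 nM

Compound 1 gives > 300000 nM, which is a limit and not a number. Of the two actual numbers, compound 2 gives 89300 nM, and compound 3 stands higher at 231000 nM.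

Compound 4 `O=S(=O)(c1ccc(Cl)cc1)n1c(-c2cn(-c3ccccc3)nc2-c2ccc(F)cc2)nc2ccccc21` is compound 3 with one change: chloro in place of hydrogen on an aromatic carbon. The chloro sits para to a large group, turning the phenylsulfonyl into a (4-chlorophenyl)sulfonyl.

Among the compounds with values here, only one measured step bears on this, and only indirectly. In an at least 3.3-fold lower number from compound 1 to compound 2 (0.52 log units; beyond the scatter), the change of trifluoromethyl in place of bromo falls at the same place and is beyond the scatter, so a group there can move the number in this assay. Within the data shown here, no measured step puts chloro in place of hydrogen, however, and compounds 1 and 2 also differ from compound 3 elsewhere on the shared core. The data therefore give no direction for this change.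

No shift beyond the scatter is expected, and the estimated change is a 1.2-fold lower number from compound 3 to compound 4 (0.06 log units; within the scatter). The estimate for compound 4 is 200000 nM, with an expected range of 90000 nM to 400000 nM.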

Compound 4, half-maximal cytotoxic concentration: 231000 nM
Compound 4: middle estimate off by 1.2-fold (0.06 log units), on the low side; the measured number falls inside the stated range.
By their numbers in this assay, from the lowest: compound 2; then compounds 3 and 4 (each within the scatter of the next). At a limit, above all of these: compound 1.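

In this assay, chloro in place of hydrogen on the phenylsulfonyl group leaves the number unmoved (no change at the digits printed from compound 3 to compound 4 (within the scatter)). Within the data shown here, this is the first measured step at this place that starts from hydrogen, and it shows that, on the shared core of compound 3 and compound 4, going from phenyl to 4-chlorophenyl does not shift the tolerated concentration beyond the scatter, whereas the only earlier step at this place, trifluoromethyl in place of bromo, exchanged one group for another and did go beyond the scatter. The compounds shown give no measured reason why the chloro leaves the number as it stands.

As far as these compounds go, whether trifluoromethyl or bromo would shift the number on the core of compound 3 stays open, as that earlier step was read on a core that differs elsewhere, so it cannot be said whether the flat result belongs to chloro alone or to this core. Also open, from the compounds shown here alone, is how this place would respond to a group of another kind, such as an amine, a carboxylic acid or a methoxy group, in place of the same hydrogen.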